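Replacing the Furanoyl Group by a Nitrile on the Shared Core

This account rests on a few compounds, and the source may have more. Where it says the series, first, only, none or still open, it means among the compounds named here.

Measured so far:
compound 1 `CC1(C)C=C(n2ccccc2=O)c2cc(C(=O)c3ccco3)ccc2O1` — 6.49
compound 2 `CC1(C)C=C(n2ccccc2=O)c2cc(C(=O)c3ccc([N+](=O)[O-])cc3)ccc2O1` — 6.2

Both compounds were tested in a functional assay (aorta) with Rattus norvegicus as the target; a higher number here means a more potent compound, by a factor of ten per unit of this negative logarithm, a lower number a less potent compound. Compound 1 gives 6.49, the highest of the two numbers, and compound 2 gives 6.2. The step of a number 0.29 log units lower from compound 1 to compound 2 (within the scatter) lies within the scatter, so these two compounds cannot be told apart in this assay.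

Compound 3 `CC1(C)C=C(n2ccccc2=O)c2cc(C#N)ccc2O1` is not yet measured. It differs from compound 1 in one place: cyano in place of (furan-2-yl)carbonyl on an aromatic carbon. Going by the values given here, the one measured step, a number 0.29 log units lower from compound 1 to compound 2 (within the scatter), kept the carbonyl and exchanged only the ring attached to it, and it was small. It does not speak directly to removing the (furan-2-yl)carbonyl altogether and putting a cyano in its place, which is a much deeper cut into the structure. With nothing closer to lean on, a modest loss is expected rather than a gain, and the step of a number 0.49 log units lower from compound 1 to compound 3 (beyond the scatter) is an estimate of that. Compound 3 is therefore expected to give about 6, most likely between 5.3 and 6.7.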

Compound 3, logarithm of the reciprocal of the active concentration, log(1/C): 7.67
Beside the measured number, compound 3's estimate is 1.67 log units below it, and the stated range ends below it.
By their numbers in this assay, from the lowest: compounds 2 and 1 (each within the scatter of the next); then compound 3.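

In this assay, the aromatic carbon of the shared core holds more than one kind of group, and the ring on the carbonyl is not needed for a high number there (a number 1.18 log units higher from compound 1 to compound 3 (beyond the scatter)). The earlier pair kept the carbonyl and exchanged only the ring attached to it (a number 0.29 log units lower from compound 1 to compound 2 (within the scatter)), so it could not show what happens when the whole (furan-2-yl)carbonyl leaves. Here a larger group with a five-membered aromatic ring gives way to cyano, a much smaller group with no ring, and the number rises by a large step instead of falling; no measurement at hand explains this rise.

A single replacement cannot separate two readings: the gain may belong to the cyano itself, or it may come from the loss of the larger (furan-2-yl)carbonyl. A plain hydrogen on this carbon would help tell these readings apart, and a methyl, a primary amide or a carboxylic acid would show how far the result depends on the cyano.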